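Sulfonyl aryl swap from compound 1 to compound 4

The source may report more compounds than this note shows. Statements on the series, on what has been measured and on what is new or still open speak of the compounds shown alone.

Compound 1 `O=C(NCc1ccc(S(=O)(=O)c2cc(F)cc(F)c2)cc1)c1cc2cnccc2[nH]1` holds the highest of the three numbers in an ADME assay on microsomes from liver (Homo sapiens) for metabolic stability, read by LC-MS, with a stated time of 30 min, tested at 1 uM (a higher number here means that more of the compound is left, a lower number that less of the compound is left), where compound 1 gives 82%. Compound 3 `O=C(NCc1ccc(S(=O)(=O)c2cc(F)cc(F)c2)cc1)c1cnc2nccn2c1` stands nearest, giving 78% in this assay, a step of a number 4 percentage points lower from compound 1 to compound 3 (within the scatter). For the measured compounds named here, compound 2 `O=C(NCc1ccc(S(=O)(=O)c2ccccc2)cc1)c1ccc2cnccc2c1` lies furthest away, giving 31% in this assay, but compound 2 differs from compound 1 in two places, so the pair yields no single step.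

Compound 4 `Cc1ccccc1S(=O)(=O)c1ccc(CNC(=O)c2cc3cnccc3[nH]2)cc1` differs from compound 1 by 2-methylphenyl in place of 3,5-difluorophenyl on a sulfonyl sulfur. Going by the values given here, the one measured step, that from compound 1 to compound 3, concerns the group on the carbonyl carbon, not the group on the sulfonyl sulfur, so no measured step bears on this change. The expectation therefore rests on compound 1 alone, with a wide range to allow for an unknown effect of the change on the sulfonyl side. Compound 4 is estimated at 65% in this assay, between 40% and 85%, which would mean an expected step of a number 17 percentage points lower from compound 1 to compound 4 (beyond the scatter).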

Compound 4, percent of the compound remaining: 48%
The estimate for compound 4 lay 17 percentage points above the measured number; low and high end bracket the measured number.
By their numbers in this assay, from the lowest: compound 2; then compound 4; then compounds 3 and 1 (each within the scatter of the next).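

For the compounds shown here, this is the first change on the sulfonyl sulfur to be read, and in this assay 2-methylphenyl in place of 3,5-difluorophenyl gives a number 34 percentage points lower from compound 1 to compound 4 (beyond the scatter), a large step beyond the scatter. The only earlier step, on the carbonyl carbon, stayed within the scatter at a number 4 percentage points lower from compound 1 to compound 3 (within the scatter), so among these compounds the group on the sulfonyl sulfur is the place where a single change has shifted the number. No measurement at hand explains the step, and the data cannot separate the loss of the two fluorines from the arrival of the methyl.

As far as these compounds go, it remains open where a 3-methylphenyl or a 2-chlorophenyl group on the sulfonyl sulfur would fall in this assay. From the compounds shown here alone, it is also open whether the same swap would give a step of similar size on the core of compound 3.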